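This account rests on a few compounds, and the source may have more. Where it says the series, first, only, none or still open, it means among the compounds named here.

Measured compounds, with their values in an in vitro ADME assay on microsomes from liver (Mus musculus) for metabolic stability, read by LC-MS; a higher number here means that the compound lasts longer, a lower number that the compound disappears faster:
compound 1, `CON/C(=N\C1=NC(=O)C(=O)N1C(C)C)Nc1ccc(Cl)c(Cl)c1`: > 1 h, a limit of this assay.
compound 2, `CC(C)N1C(=O)C(=O)N=C1/N=C(\NOCc1ccccc1)Nc1ccc(Cl)c(Cl)c1`: > 1 h, a limit of this assay.
compound 3, `CC(C)N1C(=O)C(=O)N=C1/N=C(\NCc1ccccc1)Nc1ccc(Cl)c(Cl)c1`: > 1 h, a limit of this assay.

Compound 3 therefore stands at the limit of > 1 h in this assay, at which 3 of the 3 values shown sit, not at a number. The three steps among the measured compounds, a step that the two limits leave unreadable from compound 1 to compound 2, a step that the two limits leave unreadable from compound 1 to compound 3 and a step that the two limits leave unreadable from compound 2 to compound 3, are all unreadable for the same reason. Compound 4, `CC(C)N1C(=O)C(=O)N=C1/N=C(\NCCCCN1CCCC1)Nc1ccc(Cl)c(Cl)c1`, differs from compound 3 by 3-(pyrrolidin-1-yl)propyl in place of phenyl on a saturated chain carbon bound to an amine nitrogen. Within the data shown here, no measured step covers a change of this kind, and none has a readable size, so the expected step that the limit leaves unreadable from compound 3 to compound 4 rests on compound 3 alone and carries wide uncertainty. For compound 4 the estimated value in this assay is 1.3 h, expected between 0.4 h and 4 h.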

Compound 4, half-life: > 1 h
Compound 4: no number, only a limit (the forecaster's own chance of this, stated with the estimate: 45%); the middle value lies beyond the limit too.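

Compound 4 gives > 1 h in this assay, a limit and not a number. Its steps from compound 1, compound 2 and compound 3 therefore cannot be read: the limit of > 1 h in this assay, at which 4 of the 4 values shown sit.

The compounds shown leave open how long any of the four actually lasts, and whether any of these changes alters that.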